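Swapping the Aryl Group on Sulfur

A few compounds are considered here, and "the series" means these few. Any claim that something is new, unique, unknown or untested is made for them only; others in the source may bear on it.

compound 1 `Clc1ccc(Sc2ncnc3[nH]cnc23)c(Cl)c1` – 21400 nM
compound 2 `Clc1ccc(Sc2ncnc3c2ncn3C2COc3ccccc3CO2)c(Cl)c1` – 12000 nM

Among the measured compounds shown here, these two numbers come from a functional assay on MCF7 cells (Homo sapiens) for antiproliferative activity, read by sulforhodamine B assay, with a stated time of 3 days (a higher number here means a weaker inhibitor, a lower number a stronger inhibitor), and are the only measurements available so far. Compound 2 stands at 12000 nM and compound 1 at 21400 nM in the same range. The two lie within the usual scatter of repeated measurements, so they cannot be ranked against each other.

The next molecule is compound 3 `Fc1ccc(Sc2ncnc3c2ncn3C2COc3ccccc3CO2)cc1` and it keeps everything in compound 2 except one group. It carries 4-fluorophenyl in place of 2,4-dichlorophenyl on a sulfur while the rest of the molecule stays the same.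

For the measured compounds named here, no measured pair shows what a change on this sulfur does, so any forecast in this assay rests on thin ground. The natural starting point is compound 2 at 12000 nM and nothing in hand points to a large shift from there. The expected change is small, a 1.2-fold higher number from compound 2 to compound 3 (0.07 log units; within the scatter) and within the scatter. Compound 3 is estimated at 14000 nM with an expected range from 5000 nM to 40000 nM.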

Compound 3, half-maximal inhibitory concentration: 11200 nM
Estimate against measurement, compound 3: 1.3-fold (0.10 log units) above; measured number inside the range.
By their numbers in this assay, from the lowest: compounds 3, 2 and 1 (each within the scatter of the next).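

In this assay, among the compounds shown here, the first measured change on this sulfur, 4-fluorophenyl in place of 2,4-dichlorophenyl, gives a 1.1-fold lower number from compound 2 to compound 3 (0.03 log units; within the scatter), so the two compounds cannot be told apart. This shows that, at least for this one exchange, the aromatic ring on the sulfur can lose both of its chlorine atoms and gain a fluorine without any change that this measurement can detect, although it shows nothing about other groups at this position. No supporting measurements are available to explain this result.

As far as these compounds go, both groups compared here are halogen-bearing phenyl rings, so it remains open whether an unsubstituted phenyl, a methoxy-bearing phenyl, a phenyl carrying an amine or a carboxylic acid, or a longer alkyl chain on the sulfur would take the number outside this range. From the compounds shown here alone, it also remains open whether any group at this position would give a step beyond the scatter, which is what would be needed to show that this part of the molecule has a real influence on the antiproliferative read-out.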